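A Chloro Added to an Amide Already at the Limit

The source may report more compounds than this note shows. Statements on the series, on what has been measured and on what is new or still open speak of the compounds shown alone.

Three compounds share one core and differ only in the ring carried on a urea or amide link. Compound 1 `COc1cc(-c2nn(-c3cccc(NC(=O)Nc4cc(C(F)(F)F)cc(C(F)(F)F)c4)c3)cc2-c2ccncc2)ccc1Cl` holds a urea to a bis(trifluoromethyl)phenyl ring, and in a functional assay on HCT-116 cells (Homo sapiens) for inhibition, read by sulforhodamine B assay, with a stated time of 48 h (on this read-out lower numbers stand for stronger inhibition of growth and higher numbers for weaker inhibition of growth), compound 1 gives 1760 nM. Compound 2 `COc1cc(-c2nn(-c3cccc(NC(=O)c4cccc(C(F)(F)F)c4)c3)cc2-c2ccncc2)ccc1Cl` instead holds an amide to a 3-(trifluoromethyl)phenyl ring. In this assay compound 2 returns only a limit, > 50000 nM, so no number is available for it. Compound 2 thus stands at the limit of > 50000 nM in this assay, at which 1 of the 2 values shown sits. Compound 3 `COc1cc(-c2nn(-c3cccc(NC(=O)c4ccc(Cl)c(C(F)(F)F)c4)c3)cc2-c2ccncc2)ccc1Cl` has not been measured yet; it differs from compound 2 by chloro in place of hydrogen on an aromatic carbon. A single chloro is a small addition, and the starting point is a compound for which only a limit is known, so there is little to build on. The expected step is an at least 1.6-fold lower number from compound 2 to compound 3 (0.22 log units; that floor lies within the scatter), modest in size, and it may well leave compound 3 in the region where only a limit is reported. On that basis compound 3 is estimated at 30000 nM in this assay, with a plausible range running from 8000 nM to 100000 nM.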

Compound 3, concentration for total growth inhibition: > 32500 nM
Compound 3: no number, only a limit; the forecaster's own chance of this, stated with the estimate: 55%; middle value at least 1.0-fold (0.03 log units) away from the limit.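

Compound 2 and compound 3 each return only a limit in this assay, not a number, so the step from one to the other cannot be read. The compounds shown leave open whether chloro in place of hydrogen on this aromatic carbon changes growth inhibition at all, and if so, in which direction and by how much.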